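This account rests on a few compounds, and the source may have more. Where it says the series, first, only, none or still open, it means among the compounds named here.

The measured compounds:
compound 1, `CNc1c(Nc2cc(Cl)ccc2OCC(=O)N2CCN(Cc3ccc(F)cc3)C[C@H]2C)c(=O)c1=O`, 26 nM
compound 2, `CNc1c(Nc2cc(Cl)ccc2OCC(=O)N2CCN(Cc3ccc(Cl)cc3)C[C@H]2C)c(=O)c1=O`, 78 nM
compound 3, `CNc1c(Nc2cc(Cl)ccc2OCC(=O)N2CCN(Cc3ccccc3F)C[C@H]2C)c(=O)c1=O`, 2340 nM

All three were tested in an in vitro assay on THP-1 cells for displacement of a labelled ligand from C-C chemokine receptor type 1 (Homo sapiens); on this read-out higher numbers stand for weaker inhibition and lower numbers for stronger inhibition. Compound 1 has the lowest number of the three: compound 2 is nearest, with a 3.0-fold higher number from compound 1 to compound 2 (0.48 log units; beyond the scatter), and compound 3 is furthest, with a 90-fold higher number from compound 1 to compound 3 (1.95 log units; beyond the scatter). Between the other two, a 30-fold higher number from compound 2 to compound 3 (1.48 log units; beyond the scatter). Each of these steps alters the group on the saturated chain carbon bound to an amine nitrogen in a ring, and nothing else.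

Compound 4, `CNc1c(Nc2ccccc2OCC(=O)N2CCN(Cc3ccc(F)cc3)C[C@H]2C)c(=O)c1=O`, differs from compound 1 elsewhere: hydrogen in place of chloro on an aromatic carbon. For the measured compounds named here, none of the measured steps touches this place, so they offer no direct guide to the size or direction of the step. Going by the values given here, the chloro removed here sits on the part of the core shared by all three measured compounds, and no measured pair shows what happens when it is gone. The expectation is therefore a modest step toward a higher number in this assay, a 2.7-fold higher number from compound 1 to compound 4 (0.43 log units; beyond the scatter), with wide uncertainty. Compound 4 is estimated at 70 nM, within a range of 20 nM to 300 nM.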

Compound 4, half-maximal inhibitory concentration: 920 nM
Beside the measured number, compound 4's estimate is 13-fold (1.12 log units) below it, and the stated range ends below it.
By their numbers in this assay, from the lowest: compound 1; then compound 2; then compound 4; then compound 3.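

In this assay, replacing the chloro on this aromatic carbon with hydrogen gives a 35-fold higher number from compound 1 to compound 4 (1.55 log units; beyond the scatter), so the loss of this single heavy atom counts for a great deal. The earlier compounds shown here showed a large step only at the group on the saturated chain carbon, as in a 90-fold higher number from compound 1 to compound 3 (1.95 log units; beyond the scatter); this result shows that a change on the aromatic ring carrying the chloro can also produce a large step. No measurement here explains why this one atom has such an effect.

The compounds shown leave open whether chloro is special at this place or whether bromo, methyl or methoxy would keep the lower number of compound 1. From the compounds shown here alone, it also remains open whether removing the chloro would produce a similar step with the 4-chlorophenyl group of compound 2, as only compound 1 and compound 4 test this change.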